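The source may hold more compounds than are shown below. What is called first, only, known or untested is meant among the compounds shown, and "the series" means these compounds.

Measured so far:
compound 1, `CCOC(=O)C1=C(C)NC(/C=C/C#N)=C(C(=O)OCC)C1c1cccc([N+](=O)[O-])c1`, in a functional assay on HEK293 cells for antagonist activity at Voltage-dependent L-type calcium channel subunit alpha-1D (Rattus norvegicus), read by FLIPR (a lower number here means a stronger inhibitor, a higher number a weaker inhibitor), compound 1 gives 45 nM
compound 2, `COC(=O)C1=C(C)NC(C)=C(C(=O)OCc2ccccc2)C1c1cccc([N+](=O)[O-])c1`, in this assay compound 2 gives 15 nM

Compound 2 holds the lower of these two numbers, and its gap to compound 1 lies beyond the usual scatter of repeated measurements, so it is the stronger inhibitor of the pair. Compound 3, `COC(=O)C1=C(C)NC(C)=C(C(=O)OCCc2ccc(Cl)cc2)C1c1cccc([N+](=O)[O-])c1`, has not yet been measured in this assay. It differs from compound 2 in one place: 4-chlorobenzyl in place of phenyl on a saturated chain carbon bound to an oxygen next to a carbonyl group. Among the measured compounds shown here, no pair of measured compounds shows a change of this kind, so the size of the step has to be guessed. The expectation is a small step, most likely within the scatter, with a slight lean toward a weaker inhibitor. For compound 3 the estimated value in this assay is 20 nM, with a range from 6 nM to 70 nM. This corresponds to an expected step of a 1.3-fold higher number from compound 2 to compound 3 (0.12 log units; within the scatter).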

Compound 3, half-maximal inhibitory concentration: 39 nM
Compound 3: middle estimate off by 2.0-fold (0.29 log units), on the low side, and the stated range covers the measured number.
By their numbers in this assay, from the lowest: compound 2; then compounds 3 and 1 (each within the scatter of the next).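

Among the compounds shown here, compound 2 and compound 3 give the first direct reading at this position. In this assay, replacing phenyl with 4-chlorobenzyl on the saturated chain carbon bound to an oxygen next to a carbonyl group gives a 2.6-fold higher number from compound 2 to compound 3 (0.41 log units; beyond the scatter) and this modest step lies beyond the scatter, so the position responds to this change, though inhibition is weakened rather than lost. Nothing measured here accounts for the size or direction of the step.

Read one bond further out, the change is benzyl to 2-(4-chlorophenyl)ethyl, so a longer chain and a chlorine arrive together and the compounds shown cannot separate their contributions. A 2-phenylethyl group without chlorine would tell these apart, and a chain ending in an amine or a carboxylic acid remains an open question.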